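Swapping an ethyl for a methoxyazetidine on the amide

The compounds below may be only part of what the source reports. "The series", "measured", "known", "first", "only" and "open" are said of these compounds alone.

Of the compounds shown here, three of one shared core have been measured in an ADME assay (Rattus norvegicus, strain Wistar Han) for pharmacokinetics; a lower number here means that more of the compound stays in the plasma, a higher number that more of the compound sits outside the plasma. Compound 1 `CCn1c(-c2cnc(C)nc2)nc2c(N[C@H]3CCN(C(=O)C4CCOC4)C3)ncnc21` gives 2.3 L/kg. Compound 2 `CCC(=O)N1CC[C@H](Oc2ncnc3c2nc(-c2cnc(C)nc2)n3CC)C1` gives 2.4 L/kg, a number that sits practically on top of compound 1 and is within the usual scatter of compound 3. Going by the values given here, compound 3 `CCn1c(-c2cnc(C)nc2)nc2c(N[C@H]3CCN(C(=O)N4CC(OC)C4)C3)ncnc21` gives 4.8 L/kg, and the one step that has been traced between these compounds is a 2.1-fold higher number from compound 1 to compound 3 (0.32 log units; beyond the scatter).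

The new compound, compound 4 `CCn1c(-c2cnc(C)nc2)nc2c(O[C@H]3CCN(C(=O)N4CC(OC)C4)C3)ncnc21`, differs from compound 2 in a single place: 3-methoxyazetidin-1-yl in place of ethyl on a carbonyl carbon. Among the compounds with values here, no measured step matches this change exactly. The closest is the step from compound 1 to compound 3, where the same 3-methoxyazetidin-1-yl group entered on the carbonyl carbon, though in place of oxolan-3-yl rather than ethyl. That step raised the number modestly and beyond the scatter, so a rise of similar size is expected here, though the starting group differs and the expectation is correspondingly uncertain. The expected step is a 1.9-fold higher number from compound 2 to compound 4 (0.27 log units; within the scatter). In this assay compound 4 is estimated at 4.5 L/kg, within a range of 2.5 L/kg to 8 L/kg.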

Compound 4, volume of distribution: 2.1 L/kg
Beside the measured number, compound 4's estimate is 2.1-fold (0.33 log units) above it, outside the stated range (below it).
By their numbers in this assay, from the lowest: compounds 4, 1, 2 and 3 (each within the scatter of the next, the first and the last beyond it).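

In this assay, 3-methoxyazetidin-1-yl in place of ethyl on a carbonyl carbon gives a 1.1-fold lower number from compound 2 to compound 4 (0.06 log units; within the scatter), so six heavy atoms in place of two leave no readable difference in this pair. The same group gave a 2.1-fold higher number from compound 1 to compound 3 (0.32 log units; beyond the scatter) in the other pair, so a rise beyond the scatter does not follow wherever it enters, and compound 3 gives 4.8 L/kg while compound 4, which carries the same group and differs from it in one other place, gives 2.1 L/kg. Nothing available explains why the two pairs part ways.

The compounds shown leave open whether the methoxy group or the azetidine ring matters here, which a plain azetidin-1-yl could help to separate. They also leave open how a longer chain such as butyl or a morpholin-4-yl group would read on this carbonyl carbon.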